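The source may hold more compounds than are shown below. What is called first, only, known or untested is meant among the compounds shown, and "the series" means these compounds.

In a functional assay on SGC-7901 cells (Homo sapiens) for antiproliferative activity, read by sulforhodamine B assay, with a stated time of 72 h (a lower number here means a stronger inhibitor, a higher number a weaker inhibitor), compound 3 `Cc1ccccc1NC(=S)N/N=C/c1ccc2ccccc2n1` gives only a limit, > 100000 nM. Compound 1 `Cc1cccc(NC(=S)N/N=C/c2ccc3ccccc3n2)c1` likewise gives only a limit, > 100000 nM. This is the limit of > 100000 nM in this assay, at which 2 of the 3 values shown sit. Compound 2 `S=C(N/N=C/c1ccc2ccccc2n1)Nc1ccc(Cl)cc1` alone gives a number, 87600 nM. Compound 4 `S=C(N/N=C/c1ccc2ccccc2n1)Nc1cccc(Cl)c1` carries 3-chlorophenyl in place of 2-methylphenyl on an amide-type nitrogen, (3-chlorophenyl in place of 2-methylphenyl on an amide-type nitrogen). Three measured steps change the group at this same place. They are an at least 1.1-fold lower number from compound 1 to compound 2 (0.05 log units; that floor lies within the scatter), an at least 1.1-fold higher number from compound 2 to compound 3 (0.05 log units; that floor lies within the scatter) and a step that the two limits leave unreadable from compound 1 to compound 3. The first two show sizes only as floors, and the third cannot be read. Among the measured compounds shown here, compound 2 is the only chlorophenyl compound measured, so compound 4 is expected to stay close to it in this assay. The expected change is small, toward a lower number, an at least 1.2-fold lower number from compound 3 to compound 4 (0.09 log units; that floor lies within the scatter). Compound 4 is estimated at 80000 nM, with an expected range of 35000 nM to 130000 nM.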

Compound 4, half-maximal inhibitory concentration: 61300 nM
Beside the measured number, compound 4's estimate is 1.3-fold (0.12 log units) above it; the range from low to high includes it.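

Among the compounds shown here, the first step at this place with a number at both ends is a 1.4-fold lower number from compound 2 to compound 4 (0.16 log units; within the scatter) and so the 3-chlorophenyl and 4-chlorophenyl groups cannot be told apart in this assay on this evidence. Against the methylphenyl compounds only floors can be given, an at least 1.6-fold lower number from compound 3 to compound 4 (0.21 log units; that floor lies within the scatter) and an at least 1.6-fold lower number from compound 1 to compound 4 (0.21 log units; that floor lies within the scatter) and neither shows a change beyond the scatter, since both of those compounds rest on a limit: the limit of > 100000 nM in this assay, at which 2 of the 4 values shown sit.

As far as these compounds go, whether a methoxy group or a nitrile on the phenyl ring would move the number clearly away from the chlorophenyl values stays open. So does the effect of a carbonyl in place of the thiocarbonyl.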